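The source may hold more compounds than are shown below. What is called first, only, known or untested is meant among the compounds shown, and "the series" means these compounds.

Compound 1 `c1ccc(-c2cn3ccnc3c(-c3ccc4ncn(C5CCCCC5)c4c3)n2)cc1` gives 65.7% in a functional assay on UACC-62 cells (Homo sapiens) for inhibition, read by sulforhodamine B assay, with a stated time of 48 h, tested at 10 uM; a lower number here means less inhibition, a higher number more inhibition at the concentration tested (going by the name of the read-out).
Compound 2 `Fc1ccc(-c2cn3ccnc3c(-c3ccc4ncn(C5CCCCC5)c4c3)n2)cc1` gives 31% in this assay.
Compound 3 `Clc1ccc(-c2cn3ccnc3c(-c3ccc4ncn(C5CCCCC5)c4c3)n2)cc1` gives 30.5% in this assay.

Among these three numbers, compound 3 stands lowest, but its nearest neighbour, compound 2, is within the scatter of it, so the two cannot be told apart; only compound 1 stands clearly higher. Compound 4 `Brc1ccc(-c2cn3ccnc3c(-c3ccc4ncn(C5CCCCC5)c4c3)n2)cc1` is the next member of the series. Its difference from compound 3 is bromo in place of chloro on an aromatic carbon.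

Two earlier steps bear on this one indirectly: a number 34.7 percentage points lower from compound 1 to compound 2 (beyond the scatter) and a number 35.2 percentage points lower from compound 1 to compound 3 (beyond the scatter), both large drops when a group entered where hydrogen had been. More directly, a number 0.5 percentage points lower from compound 2 to compound 3 (within the scatter) shows that exchanging one such group for another at the same place moved nothing beyond the scatter. By that analogy, the swap of chloro for bromo is expected to give a number 0.5 percentage points lower from compound 3 to compound 4 (within the scatter), that is, no step beyond the scatter. Compound 4 is therefore estimated to give 30% in this assay, with a range from 17% to 45%.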

Compound 4, a percentage reported as inhibition, at one concentration (the size of the read-out at that concentration, not a potency): 46.9%
The estimate for compound 4 lay 16.9 percentage points below the measured number, outside the stated range (above it).
By their numbers in this assay, from the lowest: compounds 3 and 2 (each within the scatter of the next); then compound 4; then compound 1.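

At this position the halogens are not interchangeable in this assay: bromo in place of chloro gives a number 16.4 percentage points higher from compound 3 to compound 4 (beyond the scatter), and bromo in place of fluoro gives a number 15.9 percentage points higher from compound 2 to compound 4 (beyond the scatter), although fluoro and chloro could not be told apart. Bromo also remains clearly separate from hydrogen, with a number 18.8 percentage points lower from compound 1 to compound 4 (beyond the scatter), so the size of the drop from hydrogen depends on which halogen is present. Nothing available explains this difference between the halogens.

Going by these compounds, it remains open whether iodo would extend the rise seen from chloro to bromo, and whether a non-halogen such as methoxy or an amine on the same carbon would behave more like hydrogen or like the halogens. These readings, each at a single concentration, also leave open how the compounds compare in potency.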